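The source may report more compounds than this note shows. Statements on the series, on what has been measured and on what is new or still open speak of the compounds shown alone.

Compound 1 `O=C(Nc1cccc(-c2oc3cc(-c4ccc(F)cc4)ccc3c(=O)c2O)c1)c1cccc(F)c1`: 15500 nM
Compound 2 `Cc1cc(C(=O)Nc2cccc(-c3oc4cc(-c5ccc(F)cc5)ccc4c(=O)c3O)c2)ccc1F`: 9540 nM
Compound 3 `O=C(Nc1cccc(-c2oc3cc(-c4ccc(F)cc4)ccc3c(=O)c2O)c1)c1cc(F)cc(F)c1`: 4960 nM

In a functional assay on HepG2 cells (Homo sapiens) for antiproliferative activity, read by CCK-8 assay, with a stated time of 72 h (on this read-out lower numbers stand for stronger inhibition and higher numbers for weaker inhibition), compound 3 stands at the low end of the three numbers. Its distance from compound 1 is a 3.1-fold lower number from compound 1 to compound 3 (0.49 log units; beyond the scatter), which is beyond the scatter, while its distance from compound 2 is a 1.9-fold lower number from compound 2 to compound 3 (0.28 log units; within the scatter), which is within it. Compound 4 `CCCc1ccc(C(=O)Nc2cccc(-c3oc4cc(-c5ccc(F)cc5)ccc4c(=O)c3O)c2)cc1` differs from compound 3 in one place: 4-propylphenyl in place of 3,5-difluorophenyl on a carbonyl carbon. Among the compounds with values here, two measured steps concern a change of the aryl group on the carbonyl carbon, namely a 1.6-fold lower number from compound 1 to compound 2 (0.21 log units; within the scatter) and a 1.9-fold lower number from compound 2 to compound 3 (0.28 log units; within the scatter), and both are within the scatter. Within the data shown here, the one step beyond the scatter, a 3.1-fold lower number from compound 1 to compound 3 (0.49 log units; beyond the scatter), came from adding a fluoro, and compound 4 carries no fluoro on that ring; no measured compound carries a propyl there. Compound 4 is therefore expected to give a somewhat higher number in this assay, estimated at 10000 nM with a range from 3000 nM to 30000 nM. That estimate corresponds to an expected step of a 2.0-fold higher number from compound 3 to compound 4 (0.30 log units; within the scatter).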

Compound 4, half-maximal inhibitory concentration: 51500 nM
Compound 4: middle estimate off by 5.2-fold (0.71 log units), on the low side; measured number outside the range, above it.
By their numbers in this assay, from the lowest: compounds 3, 2 and 1 (each within the scatter of the next, the first and the last beyond it); then compound 4.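

In this assay, the aryl group on this carbonyl carbon moves the number well beyond the scatter: the change to 4-propylphenyl gives a 10-fold higher number from compound 3 to compound 4 (1.02 log units; beyond the scatter), a 5.4-fold higher number from compound 2 to compound 4 (0.73 log units; beyond the scatter) and a 3.3-fold higher number from compound 1 to compound 4 (0.52 log units; beyond the scatter). Within the data shown here, compound 4 is therefore the weakest of the four, and the fluorinated aryl groups of the earlier compounds all give lower numbers than this alkyl-bearing ring. Among these compounds, nothing on hand bears on why this replacement raises the number so far.

The compounds shown do not separate the arrival of the propyl chain from the loss of fluoro, since compound 4 differs from the others in both at once. From the compounds shown here alone, it remains open how an unsubstituted phenyl, an ethyl or butyl chain in place of the propyl, or an amine on this ring would compare.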